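Swapping a methoxy for a methyl on the aniline ring

The compounds below may be only part of what the source reports. "The series", "measured", "known", "first", "only" and "open" are said of these compounds alone.

Of the compounds shown here, three sharing one core have been tested in a functional assay on ECa-109 cells (Homo sapiens) for inhibition, read by MTT assay, with a stated time of 72 h; a lower number here means a stronger inhibitor, a higher number a weaker inhibitor. Compound 1 `CC(C)c1ccc(-c2nc(SCc3cn(CC(=O)NC(=O)Nc4ccccn4)nn3)nc(Nc3ccccc3Cl)c2C#N)cc1` gives 23400 nM. Compound 2 `CC(C)c1ccc(-c2nc(SCc3cn(CC(=O)NC(=O)Nc4ccccn4)nn3)nc(Nc3cccc(Cl)c3)c2C#N)cc1`, which carries a 3-chlorophenyl in place of the 2-chlorophenyl on the ring nitrogen, gives 13300 nM, so the step of a 1.8-fold lower number from compound 1 to compound 2 (0.25 log units; within the scatter) does not exceed the scatter. Compound 3 `COc1ccc(Nc2nc(SCc3cn(CC(=O)NC(=O)Nc4ccccn4)nn3)nc(-c3ccc(C(C)C)cc3)c2C#N)cc1`, with a 4-methoxyphenyl on that nitrogen, gives 5420 nM. It holds the lowest of the three numbers, with the steps of a 4.3-fold lower number from compound 1 to compound 3 (0.64 log units; beyond the scatter) and a 2.5-fold lower number from compound 2 to compound 3 (0.39 log units; beyond the scatter) both beyond the scatter, so among these three it is the strongest inhibitor.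

Compound 4 `Cc1ccc(Nc2nc(SCc3cn(CC(=O)NC(=O)Nc4ccccn4)nn3)nc(-c3ccc(C(C)C)cc3)c2C#N)cc1` has not yet been measured in this assay. It differs from compound 3 in one place: methyl in place of methoxy on an aromatic carbon. Among the measured compounds shown here, none of the measured steps swaps a methoxy for a methyl; the three known steps all concern the chlorine position or the chlorine-to-methoxy exchange on this same ring, and they were modest at most. A small group on an aromatic carbon replaced by another small group is therefore expected to shift the number little, with a slight lean towards a weaker inhibitor since the methoxy is part of what set compound 3 apart. Compound 4 is estimated at 7500 nM, in the range 3000 nM to 19000 nM, which corresponds to an expected step of a 1.4-fold higher number from compound 3 to compound 4 (0.14 log units; within the scatter).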

Compound 4, half-maximal inhibitory concentration: 6700 nM
Compound 4: the middle estimate sits 1.1-fold (0.05 log units) above what was measured; the measured number falls inside the stated range.
By their numbers in this assay, from the lowest: compounds 3, 4, 2 and 1 (each within the scatter of the next, the first and the last beyond it).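

In this assay, replacing the methoxy with a methyl at this place, para to a large group, removes an oxygen and the one hydrogen-bond acceptor it counts for, yet the result is only a 1.2-fold higher number from compound 3 to compound 4 (0.09 log units; within the scatter), so this change leaves the number effectively unmoved. The methyl also alters how the series reads against the chlorinated compounds: the comparison with the 3-chlorophenyl is a 2.0-fold lower number from compound 2 to compound 4 (0.30 log units; within the scatter), while the one with the 2-chlorophenyl is a 3.5-fold lower number from compound 1 to compound 4 (0.54 log units; beyond the scatter), so the 4-methylphenyl compound separates clearly only from the 2-chlorophenyl compound, whereas compound 3 separates from both. No supporting measurement is available to explain why methoxy and methyl behave alike here.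

The compounds shown leave open whether an amine, a carboxylic acid or a longer chain such as butoxy at this same place would move the number any further than methoxy or methyl do. They also leave open how a chlorine at this place would compare, which would show whether the gap between the chlorinated compounds and compound 3 comes from the position of the group or from the chlorine itself.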